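Phenoxy in place of benzoyl at the linking aromatic carbon

The source may report more compounds than this note shows. Statements on the series, on what has been measured and on what is new or still open speak of the compounds shown alone.

Measured compounds:
compound 1 `COc1ccc(S(=O)(=O)c2ccccc2Cc2c3c(n(CC(=O)O)c2C)CCNC3=O)cc1` – 3.9 nM
compound 2 `CCS(=O)(=O)c1ccccc1Cc1c2c(n(CC(=O)O)c1C)CCNC2=O` – 550 nM
compound 3 `Cc1c(Cc2ccccc2C(=O)c2ccccc2)c2c(n1CC(=O)O)CCNC2=O` – 810 nM

All three share one core and differ only in the group carried on the aromatic carbon of the benzyl arm. In a functional assay on CHO.K1 cells for antagonist activity at prostaglandin D2 receptor 2 (Homo sapiens), read by GTPgammaS binding, with a stated time of 1 h (a higher number here means a weaker inhibitor, a lower number a stronger inhibitor), compound 1 gives 3.9 nM, the lowest of the three numbers. Compound 3 stands at the highest number of the three, with compound 2 nearest: the step of a 1.5-fold higher number from compound 2 to compound 3 (0.17 log units; within the scatter) is within the scatter, so the two cannot be told apart. The step of a 210-fold higher number from compound 1 to compound 3 (2.32 log units; beyond the scatter) is large.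

Compound 4 `Cc1c(Cc2ccccc2Oc2ccccc2)c2c(n1CC(=O)O)CCNC2=O` is not yet measured. It differs from compound 3 by phenoxy in place of benzoyl on an aromatic carbon. Within the data shown here, the steps that bear on this change are a 210-fold higher number from compound 1 to compound 3 (2.32 log units; beyond the scatter) and a 1.5-fold higher number from compound 2 to compound 3 (0.17 log units; within the scatter): a bulky sulfonyl-linked phenyl sits far below, while an ethylsulfonyl and a benzoyl sit together at the weak end. Phenoxy keeps a single phenyl on one linking atom, like benzoyl, so in this assay compound 4 is expected to stay near compound 3, with the expected step of a 1.1-fold higher number from compound 3 to compound 4 (0.05 log units; within the scatter) not clearly beyond the scatter. The estimated value for compound 4 is 900 nM, with a range from 300 nM to 3000 nM.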

Compound 4, half-maximal inhibitory concentration: 530 nM
The estimate for compound 4 lay 1.7-fold (0.23 log units) above the measured number, within the range that was stated.
By their numbers in this assay, from the lowest: compound 1; then compounds 4, 2 and 3 (each within the scatter of the next).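

In this assay, a 1.5-fold lower number from compound 3 to compound 4 (0.18 log units; within the scatter) and a 1.0-fold lower number from compound 2 to compound 4 (0.02 log units; within the scatter) both lie within the scatter, so phenoxy cannot be told apart from benzoyl or ethylsulfonyl at this aromatic carbon. Replacing the carbonyl link with an oxygen link, while keeping the phenyl ring, therefore does not bring the number close to that of the (4-methoxyphenyl)sulfonyl group, as a 140-fold higher number from compound 1 to compound 4 (2.13 log units; beyond the scatter) is large. No measurement here explains this gap.

The compounds shown do not separate the contribution of the sulfonyl link from that of the methoxy group in compound 1, since each of the other compounds lacks both. A plain phenylsulfonyl group, or a phenoxy group carrying a methoxy, would be needed to tell which of the two matters.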